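A few compounds are considered here, and "the series" means these few. Any claim that something is new, unique, unknown or untested is made for them only; others in the source may bear on it.

Measured compounds:
Compound 1, `C1CCC(Nc2nc3nonc3nc2NC2CCCC2)C1`, in an assay on mitochondria from L6 cells (Rattus norvegicus) for activation, with a stated time of 90 min; on this read-out higher numbers stand for an effect only at larger amounts of compound and lower numbers for an effect already at smaller amounts: 45000 nM.
Compound 2, `Cc1ccc(Nc2nc3nonc3nc2Nc2ccc(C)cc2)cc1`, gives > 20000 nM, a limit of the assay.
Compound 3, `Fc1ccccc1Nc1nc2nonc2nc1NCCC(F)(F)F`, gives > 100000 nM, also a limit of the assay.

Compound 3 thus stands at the limit of > 100000 nM in this assay, at which 1 of the 3 values shown sits, the weakest end of what this assay reports, with no number of its own. Compound 4, `CCOc1ccc(Nc2nc3nonc3nc2Nc2ccccc2F)cc1`, is not yet measured. It differs from compound 3 in one place: 4-ethoxyphenyl in place of 3,3,3-trifluoropropyl on a nitrogen on an aromatic ring. For the measured compounds named here, no step between measured compounds is recorded here. Compound 2, which also carries two aryl groups on the shared core, sits at the limit of > 20000 nM in this assay, at which 1 of the 3 values shown sits. The step from compound 3 to compound 4 is expected to be an at least 2.0-fold lower number from compound 3 to compound 4 (0.30 log units; that floor lies within the scatter), toward a somewhat smaller concentration. Compound 4 is estimated at 50000 nM, between 15000 nM and 200000 nM.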

Compound 4, half-maximal effective concentration: 3800 nM
Compound 4: the middle estimate sits 13-fold (1.12 log units) above what was measured, and the stated range ends above it.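

Putting 4-ethoxyphenyl in place of 3,3,3-trifluoropropyl on a nitrogen on an aromatic ring gives, in this assay, an at least 26-fold lower number from compound 3 to compound 4 (1.42 log units; beyond the scatter). For the compounds shown here, this is the first recorded step between measured compounds, and it shows that the read-out responds strongly to the group at this position. Compound 3 has only a limit, so the size of the step is a floor: the limit of > 100000 nM in this assay, at which 1 of the 4 values shown sits.

On these data alone, whether the gain comes from the aromatic ring or from its ethoxy group stays open. As far as these compounds go, how an unsubstituted phenyl, a 4-methoxyphenyl or a chain ending in an amine would read at this nitrogen also remains unknown.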